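Carbamoyl benzoxazolone acid ceramidase inhibitors: aryl substitution notes

The source may hold more compounds than are shown below. What is called first, only, known or untested is meant among the compounds shown, and "the series" means these compounds.

Measured compounds:
compound 1 `O=C(c1ccccc1)c1ccc2c(c1)oc(=O)n2C(=O)NCCCCc1ccccc1` 29 nM
compound 2 `O=C(NCCCCc1ccc2ccccc2c1)n1c(=O)oc2ccccc21` 71 nM
compound 3 `O=C(NCCCCc1ccccc1)n1c(=O)oc2ccc(-c3ccccc3)cc21` 42 nM

All three were measured in an assay on HEK293 cells for inhibition of acid ceramidase (Homo sapiens), with a stated time of 10 min; a lower number here means a stronger inhibitor, a higher number a weaker inhibitor. Compound 1 gives the lowest of the three numbers in this assay, but its gap to compound 3 lies within the usual scatter, so the two cannot be ranked against each other. Its gap to compound 2 lies beyond the scatter; compound 2 carries the naphthyl chain on the unsubstituted core, whereas compound 1 and compound 3 keep the phenylbutyl chain and carry the benzoyl or phenyl group on the core.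

Compound 4 `O=C(c1ccc(Cl)cc1)c1ccc2c(c1)oc(=O)n2C(=O)NCCCCc1ccccc1` is the next member of the set. Relative to compound 1 the change is chloro in place of hydrogen on an aromatic carbon, para to a large group, so that the benzoyl becomes (4-chlorophenyl)carbonyl. For the measured compounds named here, no step of this kind has been measured, so nothing in the data fixes its direction. The expected step from compound 1 to compound 4 in this assay is a 1.3-fold lower number from compound 1 to compound 4 (0.12 log units; within the scatter), a change not clearly beyond the scatter. Compound 4 is therefore expected to give about 22 nM in this assay, with a range from 8 nM to 60 nM.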

Compound 4, half-maximal inhibitory concentration: 14 nM
Compound 4: middle estimate off by 1.6-fold (0.20 log units), on the high side; measured number inside the range.
By their numbers in this assay, from the lowest: compound 4; then compounds 1, 3 and 2 (each within the scatter of the next, the first and the last beyond it).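

In this assay, for the compounds shown here, the change from benzoyl to (4-chlorophenyl)carbonyl gives a 2.1-fold lower number from compound 1 to compound 4 (0.32 log units; beyond the scatter) and is the first step that can be read at a single place. The earlier compounds shown here differ from each other in more than one place, so they said nothing about this aromatic carbon, para to a large group, on the benzoyl phenyl ring. This carbon now proves open to substitution: one added chlorine atom leaves the compound active, and the number moves down by more than the usual scatter, though the step is modest. Nothing measured on these compounds bears on why chloro has this effect.

Going by these compounds, one substituent at one carbon cannot show whether the step belongs to chloro itself, so fluoro, methyl, methoxy, an amine or a carboxylic acid on the same carbon remain open. On these data alone, it also remains open whether chloro on the phenyl group of compound 3 or on the naphthyl chain of compound 2 would give a step of the same direction and size.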